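The source may hold more compounds than are shown below. What is called first, only, known or untested is meant among the compounds shown, and "the series" means these compounds.

The three compounds measured share one core, and they differ only in the group attached to a double-bonded ring carbon of that core. Compound 1 `N#CC1=C(NCC(=O)N2CCCC2)N(c2ccccc2)C(=O)N2CCCCC(N3CCCC3)C12` gives 40.1% in a functional assay on the whole organism (strain albino) for inhibition, with Rattus norvegicus as the target, read by paw edema, with a stated time of 1 h, at a dose of 20 mmol/kg by the intraperitoneal route; a higher number here means more inhibition at the dose given (going by the name of the read-out), a lower number less inhibition. Among the three numbers it stands second highest; compound 2 `N#CC1=C(/N=C/Nc2ccccc2)N(c2ccccc2)C(=O)N2CCCCC(N3CCCC3)C12` gives 35.2%, and a number 4.9 percentage points lower from compound 1 to compound 2 (within the scatter), while compound 3 `N#CC1=C(/N=C/c2ccc([N+](=O)[O-])cc2)N(c2ccccc2)C(=O)N2CCCCC(N3CCCC3)C12` gives 66%, and a number 25.9 percentage points higher from compound 1 to compound 3 (beyond the scatter). Between the two aryl-bearing compounds, a number 30.8 percentage points higher from compound 2 to compound 3 (beyond the scatter).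

Compound 4 `N#CC1=C(NC(=O)c2ccccc2O)N(c2ccccc2)C(=O)N2CCCCC(N3CCCC3)C12` has not yet been measured. It differs from compound 1 in one place: (2-hydroxyphenyl)carbonyl in place of ((pyrrolidin-1-yl)carbonyl)methyl on an amine nitrogen. Both measured steps out of compound 1 bear on this change, since each of them also replaces the ((pyrrolidin-1-yl)carbonyl)methyl group with a group carrying a six-membered aromatic ring: one step stayed within the scatter, the other was modest and upward. Compound 4 carries a hydroxy-bearing aromatic ring rather than an anilino or 4-nitrophenyl group, so the two measured steps give only a loose guide.

On that basis, the step from compound 1 to compound 4 is expected to be a number 7.9 percentage points higher from compound 1 to compound 4 (within the scatter), small and uncertain in direction. Compound 4 is therefore estimated at 48% in this assay, with a range from 30% to 68%.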

Compound 4, a percentage reported as inhibition, in the whole organism at one dose (the size of the read-out at that dose, not a potency): 44.7%
Beside the measured number, compound 4's estimate is 3.3 percentage points above it; the range from low to high includes it.
By their numbers in this assay, from the lowest: compounds 2, 1 and 4 (each within the scatter of the next); then compound 3.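

Replacing ((pyrrolidin-1-yl)carbonyl)methyl with (2-hydroxyphenyl)carbonyl on the amine nitrogen leaves the reading in this assay essentially unchanged, with a number 4.6 percentage points higher from compound 1 to compound 4 (within the scatter), so this position accepts either a non-aromatic ring or a six-membered aromatic ring without a clear shift. The other two comparisons point the same way: a number 9.5 percentage points higher from compound 2 to compound 4 (within the scatter), whereas a number 21.3 percentage points lower from compound 3 to compound 4 (beyond the scatter), so an aromatic ring in this part of the molecule does not by itself bring the high number of compound 3, as compound 2 and compound 4 both carry such a ring without reaching it. No measurement at hand explains why compound 3 stands apart.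

The compounds shown leave open whether the nitro group or the carbon double-bonded to nitrogen matters more, since compound 3 differs from compound 4 in both, and (4-nitrophenyl)carbonyl on the same amine nitrogen would separate the two. Going by these compounds, the contribution of the hydroxy group in compound 4 is also open, and a plain phenylcarbonyl group at that nitrogen would address it.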